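Rearranging the hydroxyalkyl substituent on the piperidine amine

This account rests on a few compounds, and the source may have more. Where it says the series, first, only, none or still open, it means among the compounds named here.

Compound 1 `O=S(=O)(NCC1CCN(CCCc2c[nH]c3ccc(-n4cnnc4)cc23)CC1)c1ccccc1` gives 12 nM in an assay on CHO cells for agonist activity at 5-hydroxytryptamine receptor 1D (Homo sapiens), read by GTPgammaS binding; on this read-out higher numbers stand for an effect only at larger amounts of compound and lower numbers for an effect already at smaller amounts. Compound 2 `c1ccc(C2CCCCN2C2CCN(CCCc3c[nH]c4ccc(-n5cnnc5)cc34)CC2)cc1` gives 4.7 nM in this assay. Compound 3 `OCCC(NC1CCN(CCCc2c[nH]c3ccc(-n4cnnc4)cc23)CC1)c1ccccc1` gives 5.1 nM in this assay.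

Compound 3 stands second among the three numbers; its gap to compound 2 lies within the scatter, while its gap to compound 1 lies beyond it, shown by the step of a 2.4-fold lower number from compound 1 to compound 3 (0.37 log units; beyond the scatter). The new compound 4 `CC(CO)(NC1CCN(CCCc2c[nH]c3ccc(-n4cnnc4)cc23)CC1)c1ccccc1` differs from compound 3 as follows: 1-(hydroxymethyl)-1-phenylethyl in place of 3-hydroxy-1-phenylpropyl on an amine nitrogen. For the measured compounds named here, no measured step touches this change; the only measured step replaces the whole substituent on the saturated ring rather than rearranging it. The atoms stay the same and the donor and acceptor count is unchanged, so compound 4 is expected to show a step of a 1.2-fold higher number from compound 3 to compound 4 (0.07 log units; within the scatter), within the scatter, with an estimated value of 6 nM, in a range from 2 nM to 18 nM.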

Compound 4, half-maximal effective concentration: 3.4 nM
For compound 4 the middle estimate is 1.8-fold (0.25 log units) above the measured one, within the range that was stated.
By their numbers in this assay, from the lowest: compounds 4, 2 and 3 (each within the scatter of the next); then compound 1.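

In this assay, rearranging the same atoms on the amine nitrogen, 1-(hydroxymethyl)-1-phenylethyl in place of 3-hydroxy-1-phenylpropyl, gives a 1.5-fold lower number from compound 3 to compound 4 (0.18 log units; within the scatter), so this change leaves the number within the scatter. The wider replacement of ((phenylsulfonyl)amino)methyl on a saturated ring carbon by (1-(hydroxymethyl)-1-phenylethyl)amino gives a 3.5-fold lower number from compound 1 to compound 4 (0.55 log units; beyond the scatter), a gap beyond the scatter, as compound 3 already showed with its own substituent. Nothing available accounts for these numbers. The compounds shown leave open whether the hydroxyl group matters here, since none carries a methoxy group or a carboxylic acid in its place.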